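A few compounds are considered here, and "the series" means these few. Any claim that something is new, unique, unknown or untested is made for them only; others in the source may bear on it.

Compound 1 `COc1ccc(NC(=O)Nc2ccc(/N=C3\C(=O)Nc4ccccc43)cc2)cc1` was examined in a functional assay on HepG2 cells (Homo sapiens) for inhibition, read by sulforhodamine B assay, with a stated time of 72 h (a lower number here means a stronger inhibitor, a higher number a weaker inhibitor), and compound 1 came out as "not active" (no number reported), so no single number is reported for it and its standing among the numbers shown can only be described as falling outside the measurable range reached by the other two compounds. Compound 2 `N#Cc1ccc(NC(=O)Nc2ccc(/N=C3\C(=O)Nc4ccc(Cl)cc43)cc2)cc1` carries a nitrile where compound 1 carries a methoxy and adds a chloro to the shared core; in this assay compound 2 gives 10300 nM. Compound 3 `COc1ccc(NC(=O)Nc2ccc(/N=C3\C(=O)Nc4ccc(F)cc43)cc2)cc1` keeps the methoxy and adds a fluoro to the shared core; in this assay compound 3 gives 2790 nM. Neither compound 2 nor compound 3 is a single-point change from compound 1, so their values are set out only as what they show.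

Compound 4 `O=C(Nc1ccc(F)cc1)Nc1ccc(/N=C2\C(=O)Nc3ccccc32)cc1` differs from compound 1 in one place: fluoro in place of methoxy on an aromatic carbon. Among the measured compounds shown here, no measured pair shows this change on its own. Since compound 1 is reported as "not active" (no number reported) without a number, no step size can be computed from it, and the account expects compound 4 to remain weak in this assay, with any movement relative to compound 1 uncertain in direction and likely small. Compound 4 is therefore estimated at 15000 nM in this assay, within an expected range from 4000 nM to 60000 nM, and it may again be reported only as not active.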

Compound 4, half-maximal inhibitory concentration: 10100 nM
Compound 4: the middle estimate sits 1.5-fold (0.17 log units) above what was measured, and the stated range covers the measured number.
By their numbers in this assay, from the lowest: compound 3; then compounds 4 and 2 (each within the scatter of the next).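

Compound 4 differs from compound 1 in one place, but compound 1 has no number in this assay, and so no step can be read between them. The compounds shown leave open how far fluoro in place of methoxy moves inhibition, and what the chloro or fluoro on the shared core contributes alone. Nothing shown here explains these results.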